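A few compounds are considered here, and "the series" means these few. Any claim that something is new, unique, unknown or untested is made for them only; others in the source may bear on it.

Series notes. Compound 1 `COc1ccc2c(/C=C(\C)C(=O)c3cc(OC)c(OC)c([Se]C)c3)c[nH]c2c1` and compound 2 `COc1cc(C(=O)/C(C)=C/c2c[nH]c3ccccc23)cc([Se]C)c1OC` share one core; compound 3 `COc1cc(C(=O)/C=C/c2cn(C)c3ccccc23)cc([N+](=O)[O-])c1OC` is built on a different core, and the difference between the two cores is not broken down here. Compound 4 `COc1ccc2c(/C=C/C(=O)c3cc(OC)c(OC)c([N+](=O)[O-])c3)cn(C)c2c1` has not yet been measured; it stands to compound 3 as compound 1 stands to compound 2.

In a functional assay on HCT-8 cells (Homo sapiens) for antiproliferative activity, read by MTT assay, with a stated time of 48 h (on this read-out higher numbers stand for weaker inhibition and lower numbers for stronger inhibition), compound 1 gives 29 nM. In this assay compound 2 gives 32 nM. The change from compound 2 to compound 1 is methoxy in place of hydrogen on an aromatic carbon, and it gave a 1.1-fold lower number from compound 2 to compound 1 (0.04 log units; within the scatter). In this assay compound 3 gives 1660 nM, the highest number of the three measured compounds; its gaps to compound 2 and to compound 1 both lie beyond the scatter.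

The change from compound 3 to compound 4 is methoxy in place of hydrogen on an aromatic carbon, the same change as from compound 2 to compound 1, and it occurs twice among the compounds shown. Among the compounds with values here, its one measured instance left the number essentially where it was. That instance sits on a different core, so its transfer to the core of compound 3 rests on a single observation and carries real uncertainty. The step from compound 3 to compound 4 is expected to be a 1.1-fold lower number from compound 3 to compound 4 (0.04 log units; within the scatter), since the same change gave a 1.1-fold lower number from compound 2 to compound 1 (0.04 log units; within the scatter). Compound 4 is therefore expected to give about 1500 nM, with a plausible range from 500 nM to 4500 nM.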

Compound 4, half-maximal inhibitory concentration: 753 nM
Compound 4: the middle estimate sits 2.0-fold (0.30 log units) above what was measured; the range from low to high includes it.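

In this assay, methoxy in place of hydrogen on an aromatic carbon gave a 2.2-fold lower number from compound 3 to compound 4 (0.34 log units; beyond the scatter), a modest step on the core of compound 3. Set beside the earlier step on the core of compound 1, this step gives no ground for saying that the change behaves differently on the two cores: the same change on two cores in this assay, a 1.1-fold lower number (0.04 log units; within the scatter) from compound 2 to compound 1 and a 2.2-fold lower number (0.34 log units; beyond the scatter) from compound 3 to compound 4, 2.0-fold (0.30 log units) apart, within the scatter of two such steps. This supports carrying the change from one core to the other only in a limited sense: the result rests on two pairs in one assay, and although only the newer step lies beyond the scatter, that contrast does not establish a real difference between the cores, nor does the agreement prove that the steps are equal or that the result extends to other cores.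

The compounds shown carry only hydrogen or methoxy at this aromatic carbon, so it stays open how an ethoxy group, a chlorine atom or an amine there would read in this assay. The two cores also differ in more than one place, and no compound shown separates those differences, so it stays open which of them, if any, bears on the size of the step.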